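The compounds below may be only part of what the source reports. "The series", "measured", "known", "first", "only" and "open" are said of these compounds alone.

Compound 1 `Clc1cncc(OC2C=C(C#Cc3ccccn3)CCC2)c1`: 1.1 nM
Compound 2 `Cc1cccc(S(=O)(=O)N2CC=C(C#Cc3ccccn3)CC2)c1`: 13 nM

Both numbers come from an assay for displacement of a labelled ligand from metabotropic glutamate receptor 5 (Rattus norvegicus); on this read-out lower numbers stand for stronger inhibition and higher numbers for weaker inhibition. Of the two measured compounds, compound 2 stands at the higher number; compound 1 sits well below it, and the gap between them is wider than the usual scatter of repeated measurements, so compound 1 is the stronger binder of the pair.

Compound 3 `Cc1ccc(S(=O)(=O)N2CC=C(C#Cc3ccccn3)CC2)cc1` is built from the same atoms as compound 2, joined differently: 4-methylphenyl in place of 3-methylphenyl on a sulfonyl sulfur. Among the compounds with values here, no measured pair in this set shows a change of this kind, so the size of the step cannot be read from the data. With the ring and its single methyl both kept, only a modest shift in this assay is expected, in either direction, and quite possibly none beyond the scatter.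

For compound 3 the expected value in this assay is 15 nM, with a range from 5 nM to 50 nM. The step implied by this estimate is a 1.2-fold higher number from compound 2 to compound 3 (0.06 log units; within the scatter).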

Compound 3, inhibition constant: 12 nM
Beside the measured number, compound 3's estimate is 1.3-fold (0.10 log units) above it, within the range that was stated.
By their numbers in this assay, from the lowest: compound 1; then compounds 3 and 2 (each within the scatter of the next).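

Placing the methyl differently on the ring, with 4-methylphenyl in place of 3-methylphenyl on a sulfonyl sulfur, gives a 1.1-fold lower number from compound 2 to compound 3 (0.03 log units; within the scatter) in this assay. Within the data shown here, this is the first pair in the set that differs in one place, and it shows that this assay does not separate these two methylphenyl groups. No separate measurement speaks to why the two groups read alike.

As far as these compounds go, whether this tolerance extends to other groups stays open: an unsubstituted phenyl, a chlorine or methoxy group on the ring, or an ethyl chain in place of the methyl could each read differently. Compound 1 differs from compounds 2 and 3 in more than one place, so its gap to them cannot be assigned to any single group.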